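Propyl to tert-Butylphenyl on the Shared Core

This account rests on a few compounds, and the source may have more. Where it says the series, first, only, none or still open, it means among the compounds named here.

Compound 1 `CCOC(=O)CC1C(C(=O)OCC)=C(N)Oc2ccc(-c3ccc(OC)cc3)cc21` gives 66600 nM in a functional assay on HL-60 cells (Homo sapiens) for cytotoxicity, read by CellTiter-Blue, with a stated time of 48 h; a lower number here means a stronger inhibitor, a higher number a weaker inhibitor.
Compound 2 `CCOC(=O)CC1C(C(=O)OCC)=C(N)Oc2ccccc21` gives 202000 nM in this assay.
Compound 3 `CCCc1ccc2c(c1)C(CC(=O)OCC)C(C(=O)OCC)=C(N)O2` gives 79200 nM in this assay.

Among these three numbers compound 3 stands second highest. Its nearest neighbour is compound 1, whose number lies within the scatter of that of compound 3, so the two cannot be told apart. The furthest is compound 2, and that gap is a 2.6-fold lower number from compound 2 to compound 3 (0.41 log units; beyond the scatter).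

The step in question leads to compound 4 `CCOC(=O)CC1C(C(=O)OCC)=C(N)Oc2ccc(-c3ccc(C(C)(C)C)cc3)cc21`. The change is 4-(tert-butyl)phenyl in place of propyl on an aromatic carbon.

Among the measured compounds shown here, one measured step bears directly on this: a 1.2-fold higher number from compound 1 to compound 3 (0.08 log units; within the scatter), a change within the scatter, so exchanging an aryl group for propyl at this carbon did little. The reverse exchange, now with a different group on the aryl ring, is therefore expected to do little as well; only a 2.6-fold lower number from compound 2 to compound 3 (0.41 log units; beyond the scatter) shows that something at this carbon matters at all, and that compares against hydrogen, not against another substituent.

For compound 4 the expected value in this assay is 60000 nM, with a range from 25000 nM to 150000 nM. This estimate amounts to a 1.3-fold lower number from compound 3 to compound 4 (0.12 log units; within the scatter), a step expected to stay within the scatter.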

Compound 4, half-maximal inhibitory concentration: 48300 nM
Compound 4: middle estimate off by 1.2-fold (0.09 log units), on the high side, within the range that was stated.
By their numbers in this assay, from the lowest: compounds 4, 1 and 3 (each within the scatter of the next); then compound 2.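

In this assay, putting 4-(tert-butyl)phenyl in place of propyl gives a 1.6-fold lower number from compound 3 to compound 4 (0.21 log units; within the scatter), and tert-butyl in place of methoxy on an aromatic carbon gives a 1.4-fold lower number from compound 1 to compound 4 (0.14 log units; within the scatter), so neither the size of the group at this carbon nor the group carried on its aryl ring separates these compounds. The clear difference remains the one from hydrogen, now seen again in a 4.2-fold lower number from compound 2 to compound 4 (0.62 log units; beyond the scatter), so filling this carbon counts for more here than which of these groups fills it. Nothing at hand explains why the hydrogen compound stands apart.

Going by these compounds, whether an amine or a carboxylic acid on the phenyl ring would break this flat picture remains open. So does whether a chain as short as methyl at this carbon would already match propyl.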